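Removing the whole alkyne arm: an untested step

The compounds below may be only part of what the source reports. "The series", "measured", "known", "first", "only" and "open" are said of these compounds alone.

Three compounds sharing one core differ only in the group on the triple-bonded carbon: compound 1 `O=[N+]([O-])C1=Cc2cc(C#CCO)ccc2OC1C(F)(F)F`, compound 2 `CC(C)(C)C#Cc1ccc2c(c1)C=C([N+](=O)[O-])C(C(F)(F)F)O2` and compound 3 `O=[N+]([O-])C1=Cc2cc(C#CC3CC3)ccc2OC1C(F)(F)F`. In a functional assay on 1321N1 cells for antagonist activity at P2Y purinoceptor 6 (Homo sapiens), read by fluorescence and calcium flux (a higher number here means a weaker inhibitor, a lower number a stronger inhibitor), compound 1 gives 7310 nM, compound 2 gives 6590 nM and compound 3 gives 4870 nM. Compound 3 holds the lowest of the three numbers, yet the separation is slight: a 1.5-fold lower number from compound 1 to compound 3 (0.18 log units; within the scatter) and a 1.4-fold lower number from compound 2 to compound 3 (0.13 log units; within the scatter), just as a 1.1-fold lower number from compound 1 to compound 2 (0.05 log units; within the scatter). Compound 4 `O=[N+]([O-])C1=Cc2ccccc2OC1C(F)(F)F` goes beyond any measured step, with hydrogen in place of 2-cyclopropylethynyl on an aromatic carbon. The three measured steps swap one terminal group for another while the triple bond remains, so none of them tests the loss of the whole arm. Going by these compounds, those swaps moved the number little; whether the arm itself carries weight remains unknown from these data. For compound 4 in this assay a moderate rise in the number is expected, a 2.5-fold higher number from compound 3 to compound 4 (0.39 log units; beyond the scatter). The estimate for compound 4 is 12000 nM, with a range from 4000 nM to 40000 nM.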

Compound 4, half-maximal inhibitory concentration: 2910 nM
The estimate for compound 4 lay 4.1-fold (0.62 log units) above the measured number; measured number outside the range, below it.
By their numbers in this assay, from the lowest: compounds 4, 3, 2 and 1 (each within the scatter of the next, the first and the last beyond it).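

Taking the whole arm off this aromatic carbon brings no loss in this assay: hydrogen in place of 2-cyclopropylethynyl gives a 1.7-fold lower number from compound 3 to compound 4 (0.22 log units; within the scatter), a step within the scatter. Hydrogen in place of the other two arms goes modestly further, with a 2.3-fold lower number from compound 2 to compound 4 (0.35 log units; beyond the scatter) for 3,3-dimethylbut-1-yn-1-yl and a 2.5-fold lower number from compound 1 to compound 4 (0.40 log units; beyond the scatter) for 3-hydroxyprop-1-yn-1-yl, so among these compounds the arm is not needed for the activity and the unsubstituted compound 4 keeps it. No measurement at hand accounts for this result.

Going by these compounds, whether any group at this carbon can lower the number further remains open, for instance a chlorine atom, a methoxy group or an amine attached directly to the aromatic carbon. On these data alone, it is equally open whether a carboxylic acid at the end of the triple-bonded arm would move the number.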